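Compound 2 to compound 3: a side-chain swap

The source may report more compounds than this note shows. Statements on the series, on what has been measured and on what is new or still open speak of the compounds shown alone.

Compound 1 (`Cn1cc(C2=C(c3nn(CCCN4CCCCC4)c4ncccc34)C(=O)N(c3ccccc3)C2=O)c2ccccc21`) gives 12300 nM
Compound 2 (`CN1CCN(CCCn2nc(C3=C(c4cn(C)c5ccccc45)C(=O)NC3=O)c3cccnc32)CC1`) gives > 100000 nM (a limit of the assay)

Both compounds were tested in a functional assay on ECa-109 cells (Homo sapiens) for antiproliferative activity, read by MTT assay, with a stated time of 48 h (a higher number here means a weaker inhibitor, a lower number a stronger inhibitor), and only compound 1 has an exact number there. For compound 2, > 100000 nM is a limit and not a number.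

Compound 3 (`Cn1cc(C2=C(c3nn(CCn4ccnc4)c4ncccc34)C(=O)NC2=O)c2ccccc21`) differs from compound 2 in one place: 1H-imidazol-1-yl in place of (4-methylpiperazin-1-yl)methyl on a saturated chain carbon, two bonds along the chain from an aromatic nitrogen. In words, 1H-imidazol-1-yl stands in place of (4-methylpiperazin-1-yl)methyl on a saturated chain carbon, two bonds along the chain from an aromatic nitrogen.

For the measured compounds named here, no two measured compounds differ in one place alone, so the data give no size for this change. Compound 1, at 12300 nM, shows that a measurable number is possible in this test. The estimated step of an at least 2.5-fold lower number from compound 2 to compound 3 (0.39 log units; beyond the scatter) is expected to be modest and towards stronger inhibition, although another limit remains possible. For compound 3 the expected value is 40000 nM (range 12000 nM to 100000 nM).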

Compound 3, half-maximal inhibitory concentration: > 100000 nM
Compound 3 ended at the assay's limit; the forecaster's own chance of this, stated with the estimate: 40%; middle value at least 2.5-fold (0.39 log units) from the limit.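

Compound 2 and compound 3 both end at a limit of the assay and not at a number, so no step between them can be read: the limit of > 100000 nM in this assay, at which 2 of the 3 values shown sit.

The compounds shown leave open whether 1H-imidazol-1-yl or (4-methylpiperazin-1-yl)methyl gives the stronger inhibitor, and by how much.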